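Alpha-methyl on the benzylic carbon: permeability outlook

This account rests on a few compounds, and the source may have more. Where it says the series, first, only, none or still open, it means among the compounds named here.

Working notes on the series. Compound 1 `CNC(=O)c1cc(C(=O)N[C@H]2CC[C@H](O)CC2)n([C@@H](C)c2ccc(Cl)cc2)n1` gives 180 nm/s in an ADME assay for permeability; a higher number here means that the compound crosses the layer faster, a lower number that the compound crosses the layer more slowly. For compound 2 `CNC(=O)c1cc(C(=O)NC2CC2)n(Cc2ccccc2)n1` the result in this assay is only a limit, > 80 nm/s, so compound 2 stands at the limit of > 80 nm/s in this assay, at which 1 of the 2 values shown sits, and no number is known. Compound 3 `CNC(=O)c1cc(C(=O)NC2CC2)n([C@@H](C)c2ccccc2)n1` differs from compound 2 by methyl in place of hydrogen on a saturated chain carbon bound to an aromatic carbon and an aromatic nitrogen. Within the data shown here, no measured step covers this change. The step that the limit leaves unreadable from compound 2 to compound 3 is expected to stay within the scatter or to lean slightly upward. Compound 3 is estimated at 150 nm/s, in the range 70 nm/s to 320 nm/s.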

Compound 3, apparent permeability in the ADME assay: > 400 nm/s
Compound 3 was reported as a limit; the forecaster's own chance of this, stated with the estimate: 35%; at least 2.6-fold (0.42 log units) between middle value and limit.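

In the ADME assay compound 2 gives > 80 nm/s as a limit of the assay. In the ADME assay compound 3 gives > 400 nm/s as a limit of the assay as well. Both results are only limits, so no step can be read between them. The compounds shown leave open how large the effect of methyl in place of hydrogen is on this read-out. In a physicochemical assay for lipophilicity (on this read-out lower numbers stand for lower lipophilicity and higher numbers for higher lipophilicity), compound 2 gives 3.1 and compound 3 gives 3.6 and so the read-out shows a number 0.50 log units higher from compound 2 to compound 3 (beyond the scatter) for methyl in place of hydrogen.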